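From a Hydroxyphenyl Biaryl to a Methoxyphenethyl Chain

The compounds below may be only part of what the source reports. "The series", "measured", "known", "first", "only" and "open" are said of these compounds alone.

Of the compounds shown here, three on a shared core have been measured in an assay on mitochondria (strain BALB/c) for inhibition of glycerol-3-phosphate acyltransferase 1, mitochondrial (Mus musculus), read by scintillation counting, with a stated time of 10 min; a lower number here means a stronger inhibitor, a higher number a weaker inhibitor. Compound 1 `CCCCCCCCS(=O)(=O)Nc1ccc(-c2ccc(OC)cc2)cc1C(=O)O` gives 19500 nM; compound 2 `CCCCCCCCS(=O)(=O)Nc1ccc(-c2cccc(F)c2)cc1C(=O)O` gives 37600 nM; compound 3 `CCCCCCCCS(=O)(=O)Nc1ccc(-c2ccc(O)cc2)cc1C(=O)O` gives 47300 nM. Compound 3 thus holds the highest of the three numbers, though its gap to compound 2 is within the scatter (a 1.3-fold higher number from compound 2 to compound 3 (0.10 log units; within the scatter)), and its gap to compound 1 only just beyond it (a 2.4-fold higher number from compound 1 to compound 3 (0.38 log units; beyond the scatter)).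

Compound 4 `CCCCCCCCS(=O)(=O)Nc1ccc(CCc2ccc(OC)cc2)cc1C(=O)O` is the unmeasured member. It differs from compound 3 in one place: 2-(4-methoxyphenyl)ethyl in place of 4-hydroxyphenyl on an aromatic carbon. Two parts of this change deserve separating. The methyl on the ring oxygen returns, and the measured step of a 2.4-fold higher number from compound 1 to compound 3 (0.38 log units; beyond the scatter) shows that removing it raised the number modestly, so putting it back would be expected to recover about as much. Going by the values given here, the two-carbon link between the rings has no counterpart among the measured compounds, and nothing in the three numbers speaks to it. A modest lowering in this assay is therefore expected, a 2.2-fold lower number from compound 3 to compound 4 (0.33 log units; beyond the scatter), with a wide band. Compound 4 is estimated at 22000 nM, between 7000 nM and 70000 nM.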

Compound 4, half-maximal inhibitory concentration: 26300 nM
Compound 4: the middle estimate sits 1.2-fold (0.08 log units) below what was measured; measured number inside the range.
By their numbers in this assay, from the lowest: compounds 1, 4, 2 and 3 (each within the scatter of the next, the first and the last beyond it).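

At this position, on an aromatic carbon meta to a carboxy group, 2-(4-methoxyphenyl)ethyl is the only group shown that holds its aromatic ring on an ethyl chain, and in this assay its number lies within the scatter of all three earlier compounds (a 1.3-fold higher number from compound 1 to compound 4 (0.13 log units; within the scatter); a 1.4-fold lower number from compound 2 to compound 4 (0.16 log units; within the scatter); a 1.8-fold lower number from compound 3 to compound 4 (0.25 log units; within the scatter)). The first of these steps is the cleanest reading of the new chain, since both compounds carry the 4-methoxyphenyl ring, and adding the ethyl chain gives no difference that can be told from the scatter. Nothing available here offers an explanation for this result.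

The compounds shown leave open whether a longer chain or a single methylene link at this position would separate from the scatter. They also leave open how 2-(4-hydroxyphenyl)ethyl or an amine on the outer ring would compare.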